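Removing a Second Methyl Group from Compound 1

A few compounds are considered here, and "the series" means these few. Any claim that something is new, unique, unknown or untested is made for them only; others in the source may bear on it.

Going by the values given here, compound 1 `COc1cc(O)c2c(c1)OC(c1ccc(OC)c(O)c1)C(OC)C2=O` stands highest of the two numbers measured so far: in a functional assay on BV-2 cells (Mus musculus) for inhibition (a higher number here means a weaker inhibitor, a lower number a stronger inhibitor), compound 1 gives 25100 nM. Its nearest neighbour is compound 2 `COc1cc(O)c2c(c1)OC(c1ccc(O)c(O)c1)C(OC)C2=O`, and in this assay compound 2 gives 4200 nM, a step of a 6.0-fold lower number from compound 1 to compound 2 (0.78 log units; beyond the scatter). Compound 3 `COc1ccc(C2Oc3cc(O)cc(O)c3C(=O)C2OC)cc1O` differs from compound 1 by the same kind of change at another place: hydrogen in place of methyl on an oxygen on an aromatic ring. Among the compounds with values here, only that one measured step bears on it, and it was modest but beyond the scatter, so a lower number, perhaps somewhat smaller in size, is expected for compound 3 in this assay. Compound 3 is therefore estimated at 8000 nM (range 3000 nM to 20000 nM), a step of a 3.1-fold lower number from compound 1 to compound 3 (0.50 log units; beyond the scatter).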

Compound 3, half-maximal inhibitory concentration: 11100 nM
Compound 3: middle estimate off by 1.4-fold (0.14 log units), on the low side, within the range that was stated.
By their numbers in this assay, from the lowest: compound 2; then compound 3; then compound 1.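

In this assay the change from methoxy to hydroxy lowers the number at a second place on the core of compound 1 (a 2.3-fold lower number from compound 1 to compound 3 (0.35 log units; beyond the scatter)). The earlier step (a 6.0-fold lower number from compound 1 to compound 2 (0.78 log units; beyond the scatter)) showed this direction at one place only, and it now holds at both places, each beyond the scatter. No measurement at hand explains why this change lowers the number at either place.

Still open, going by these compounds, is whether the two changes add up when both methyl groups are replaced by hydrogen. On these data alone, it is also open whether a longer chain such as ethoxy on that oxygen would keep the number low.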